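The source may report more compounds than this note shows. Statements on the series, on what has been measured and on what is new or still open speak of the compounds shown alone.

Compound 1 `CC(C)(C)c1ccc(OC(C)(C)C2OCC(C/C=C\CCC(=O)O)C(c3cccnc3)O2)cc1`: 1910 nM
Compound 2 `Cc1ccc(OC(C)(C)C2OCC(C/C=C\CCC(=O)O)C(c3cccnc3)O2)cc1`: 631 nM

Among the compounds with values here, in a functional assay for inhibition, with Homo sapiens as the target (a lower number here means tighter binding, a higher number weaker binding), compound 2 gives 631 nM and so holds the lower of the two numbers measured so far. Compound 3 `CSc1ccccc1OC(C)(C)C1OCC(C/C=C\CCC(=O)O)C(c2cccnc2)O1` has not yet been measured. Its difference from compound 2 is 2-(methylsulfanyl)phenyl in place of 4-methylphenyl on an oxygen on a saturated carbon and, in words, 2-(methylsulfanyl)phenyl in place of 4-methylphenyl on an oxygen on a saturated carbon. Within the data shown here, only one measured step offers any guide: a 3.0-fold lower number from compound 1 to compound 2 (0.48 log units; beyond the scatter) (methyl in place of tert-butyl on an aromatic carbon). That step was modest but beyond the scatter. It involved a different pair of groups, so it suggests a size and not a direction. The estimated move is a 1.6-fold lower number from compound 2 to compound 3 (0.20 log units; within the scatter) and it is expected to be similarly modest, leaning lower only as a guess. Compound 3 is expected at 400 nM with a range from 100 nM to 1500 nM in this assay once measured.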

Compound 3, dissociation constant: 89.1 nM
Beside the measured number, compound 3's estimate is 4.5-fold (0.65 log units) above it, and the stated range ends above it.
By their numbers in this assay, from the lowest: compound 3; then compound 2; then compound 1.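

Compound 1 and compound 2 showed only a swap of tert-butyl for methyl on the aromatic ring, while compound 3 shows that the whole group on this oxygen can be exchanged and the number in this assay still falls. Putting 2-(methylsulfanyl)phenyl in place of 4-methylphenyl brings a 7.1-fold lower number from compound 2 to compound 3 (0.85 log units; beyond the scatter) and, set against the 4-(tert-butyl)phenyl group, a 21-fold lower number from compound 1 to compound 3 (1.33 log units; beyond the scatter), so this position responds strongly to what it carries. Nothing at hand explains why this change helps.

The new group differs from the old in two ways at once, holding a sulfur and sitting under a different number in its name, so these compounds cannot separate the two. A 2-methylphenyl or a 4-(methylsulfanyl)phenyl group would be needed to tell them apart, and a 2-methoxyphenyl group would test whether the sulfur itself matters.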